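Swapping a pyridine for cyclohexane on the piperazine end

The source may report more compounds than this note shows. Statements on the series, on what has been measured and on what is new or still open speak of the compounds shown alone.

Of the compounds shown here, three sharing the same benzamide core have been measured in a functional assay on MGC-803 cells (Homo sapiens) for antiproliferative activity, read by CCK-8 assay, with a stated time of 72 h, tested at 2 uM; a higher number here means a stronger effect of the compound at the concentration tested, a lower number a weaker effect. Compound 1, `Nc1ccccc1NC(=O)c1ccc(CSC(=S)N2CCN(c3cccnc3)CC2)cc1`, gives 27.6% in this assay, the lowest of the three numbers. Compound 2, `CN(C(=S)SCc1ccc(C(=O)Nc2ccccc2N)cc1)c1cccnc1`, gives 46.1% in this assay, and compound 3, `Nc1ccccc1NC(=O)c1ccc(CSC(=S)N2CCc3cc(Cl)ccc32)cc1`, gives 57.7% in this assay; both stand beyond the scatter above compound 1. Going by the values given here, the one single-point step on record, a number 11.6 percentage points higher from compound 2 to compound 3 (beyond the scatter), exchanges a methyl(pyridin-3-yl)amino group on the thiocarbonyl carbon for a 5-chloro-2,3-dihydro-1H-indol-1-yl group, so it is the only measured case in which a pyridin-3-yl group leaves, and it moved the number up by a modest amount.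

Compound 4, `Nc1ccccc1NC(=O)c1ccc(CSC(=S)N2CCN(C3CCCCC3)CC2)cc1`, differs from compound 1 by cyclohexyl in place of pyridin-3-yl on an amine nitrogen in a ring. This change also removes a pyridin-3-yl group, though on the amine nitrogen in the ring rather than on the thiocarbonyl carbon, so the step from compound 2 to compound 3 bears on it only loosely. On that basis a modest rise beyond the scatter is expected, a number 10.4 percentage points higher from compound 1 to compound 4 (beyond the scatter). Compound 4 is therefore estimated to give 38% in this assay, within a range from 22% to 55%.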

Compound 4, a percentage reported as inhibition, at one concentration (the size of the read-out at that concentration, not a potency): 16.9%
For compound 4 the middle estimate is 21.1 percentage points above the measured one; the measured number lies below the stated range.
By their numbers in this assay, from the lowest: compound 4; then compound 1; then compound 2; then compound 3.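

On the amine nitrogen in the ring, cyclohexyl in place of pyridin-3-yl gives a number 10.7 percentage points lower from compound 1 to compound 4 (beyond the scatter) in this assay, so at this position the pyridin-3-yl group is the better of the two. Removing a pyridin-3-yl group therefore has no single direction in this series: the earlier step, a number 11.6 percentage points higher from compound 2 to compound 3 (beyond the scatter), went the other way, although it replaced a different group and brought in a 5-chloro-2,3-dihydro-1H-indol-1-yl group. The new step exchanges an aromatic ring with one hetero atom and one hydrogen-bond acceptor for a non-aromatic ring of carbon only, with the same number of heavy atoms, and nothing available here shows which of these differences matters for the drop.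

On these data alone, what a phenyl group, a pyridin-4-yl group or a short chain such as methyl would give on this same amine nitrogen remains open, and with it whether the ring nitrogen or the aromatic ring is what separates compound 1 from compound 4. Also open, as far as these compounds go, is whether the order of these two compounds at one concentration would hold for their potency.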